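From Azetidin-1-yl to (2-Fluorophenyl)amino on the Shared Core

A few compounds are considered here, and "the series" means these few. Any claim that something is new, unique, unknown or untested is made for them only; others in the source may bear on it.

Compound 2 `O=C1C=C(N2CCC2)C(=O)c2c1nc1n2[C@H]2OC[C@@H](O)[C@H]2OC1` is the starting point. In a functional assay on HeLa cells (Homo sapiens) for inhibition, read by sulforhodamine B assay (a lower number here means a stronger inhibitor, a higher number a weaker inhibitor), compound 2 gives only a limit of the assay, > 16000 nM. Its one measured relative, compound 1 `O=C1C=C(NCc2ccccc2)C(=O)c2c1nc1n2[C@H]2OC[C@@H](O)[C@H]2OC1`, is also reported only as a limit; in this assay compound 1 gives > 8000 nM. The step between them, a step that the two limits leave unreadable from compound 1 to compound 2, cannot be sized, since both values sit at limits, namely the limit of > 16000 nM in this assay, at which 1 of the 2 values shown sits, and (the limit of > 8000 nM in this assay, at which 1 of the 2 values shown sits). Compound 3 `O=C1C=C(Nc2ccccc2F)C(=O)c2c1nc1n2[C@H]2OC[C@@H](O)[C@H]2OC1` has not yet been measured; it differs from compound 2 by (2-fluorophenyl)amino in place of azetidin-1-yl on a double-bonded ring carbon. No measured step resembles this change, and the only step shown is unreadable, so the data give no direction for it. Compound 3 is therefore expected to remain weak, with an estimated step of an at least 1.3-fold lower number from compound 2 to compound 3 (0.12 log units; that floor lies within the scatter). The estimate for compound 3 is 12000 nM, with an expected range from 2500 nM to 50000 nM.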

Compound 3, half-maximal inhibitory concentration: 5120 nM
The estimate for compound 3 lay 2.3-fold (0.37 log units) above the measured number, and the stated range covers the measured number.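

Among these compounds, compound 3 is the first compound here to give a measured number rather than a limit in this assay, showing that a group at this double-bonded ring carbon can bring measurable inhibition. Putting (2-fluorophenyl)amino in place of azetidin-1-yl gives an at least 3.1-fold lower number from compound 2 to compound 3 (0.49 log units; beyond the scatter), whereas 2-fluorophenyl in place of benzyl on the amine nitrogen gives an at least 1.5-fold lower number from compound 1 to compound 3 (0.19 log units; that floor lies within the scatter), so this second comparison does not yet establish a real gain, and its true size is hidden by a limit for compound 1. Compound 2 also stands at a limit, so the first step is only a floor: the limit of > 16000 nM in this assay, at which 1 of the 3 values shown sits.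

As far as these compounds go, whether the fluorine matters remains open, and phenylamino, without it, would be the direct comparison. So does the role of the amine hydrogen, which an N-methyl-N-phenylamino group would test.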